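Replacing One Aryl Group of Compound 3

The source may report more compounds than this note shows. Statements on the series, on what has been measured and on what is new or still open speak of the compounds shown alone.

Of the compounds shown here, three on a shared core have been measured in an ADME assay on microsomes from liver (Rattus norvegicus) for metabolic stability, read by LC-MS, with a stated time of 1 h, at 37 degrees C, tested at 4 uM (a lower number here means that less of the compound is left, a higher number that more of the compound is left), so far. Compound 1 (`O=C(O)c1ccc(Cl)c(-c2cccc(COc3ccc4c(c3)CN(C3CCCC3)C4=O)c2)c1`) has 15% left at the end, and compound 2 (`O=C(O)c1cc(F)cc(-c2cccc(COc3ccc4c(c3)CN(C3CCCC3)C4=O)c2)c1`) has 55% left. Compound 3 (`Cc1ccc(C(=O)O)cc1-c1cccc(COc2ccc3c(c2)CN(C2CCCC2)C3=O)c1`) has 2% left, the lowest of the three numbers.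

Compound 4 (`O=C(O)c1ccc(-c2cccc(COc3ccc4c(c3)CN(C3CCCC3)C4=O)c2)c(Cl)c1`) has not been measured yet. It differs from compound 3 in one group (4-carboxy-2-chlorophenyl in place of 5-carboxy-2-methylphenyl on an aromatic carbon): 4-carboxy-2-chlorophenyl in place of 5-carboxy-2-methylphenyl, on an aromatic carbon meta to a large group.

Like compound 1, compound 4 carries a chloro group rather than a methyl. Going from chloro to methyl gave a number 13 percentage points lower from compound 1 to compound 3 (beyond the scatter) as a modest step, so undoing that swap points upward. Among the compounds with values here, no measured pair isolates where the carboxy group sits. Still, two large steps show how much this ring can matter: a number 40 percentage points higher from compound 1 to compound 2 (beyond the scatter) and a number 53 percentage points lower from compound 2 to compound 3 (beyond the scatter) both change the ring's other group as well.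

A modest to moderate rise is therefore expected, with a wide margin. The expected step is a number 18 percentage points higher from compound 3 to compound 4 (beyond the scatter) in this assay as a rough guide. For compound 4 the estimate is 20% with an expected range of 6% to 45% remaining.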

Compound 4, percent of the compound remaining: 3%
For compound 4 the middle estimate is 17 percentage points above the measured one; measured number below the stated range.
By their numbers in this assay, from the lowest: compounds 3 and 4 (each within the scatter of the next); then compound 1; then compound 2.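

In this assay, a chloro group on this ring does not by itself set the number apart from a methyl group: exchanging the 5-carboxy-2-methylphenyl ring for the 4-carboxy-2-chlorophenyl ring gives a number 1 percentage points higher from compound 3 to compound 4 (within the scatter). The 5-carboxy-2-chlorophenyl and 4-carboxy-2-chlorophenyl rings carry the same two groups in different arrangements, so this is the only pair shown that isolates where the carboxy group sits, and it gives a number 12 percentage points lower from compound 1 to compound 4 (beyond the scatter). The 3-carboxy-5-fluorophenyl ring remains far from the new ring, with a number 52 percentage points lower from compound 2 to compound 4 (beyond the scatter), and of the four rings shown it alone gives a number this high.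

No measurement available here explains why these rings differ. The compounds leave open whether the arrangement in the 3-carboxy-5-fluorophenyl ring would hold its number with a chloro or methyl group in place of the fluoro, and whether a nitrile or an amine could take the place of the carboxylic acid on this ring.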